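The source may report more compounds than this note shows. Statements on the series, on what has been measured and on what is new or still open speak of the compounds shown alone.

Measured compounds:
Compound 1 `CN1CCN(c2ccc(NCc3ccccc3O)cc2)CC1` — "not active" (no number reported)
Compound 2 `Oc1ccccc1CNc1ccc(-c2cccc(Cl)c2)cc1` — 6200 nM
Compound 3 `Cc1cccc(-c2ccc(NCc3ccccc3O)cc2)c1` — 9190 nM

In a functional assay on Jurkat cells (Homo sapiens) for activation, with a stated time of 24 h (a higher number here means that more compound is needed for the effect, a lower number that less compound is needed), compound 1 gave no number and is reported only as "not active" (no number reported). Compound 2 gave 6200 nM and compound 3 gave 9190 nM, which stands as the higher of the two numbers, though the difference a 1.5-fold higher number from compound 2 to compound 3 (0.17 log units; within the scatter) lies within the scatter. Compound 4 `Oc1cccc(-c2ccc(NCc3ccccc3O)cc2)c1` has not yet been measured. It differs from compound 3 by hydroxy in place of methyl on an aromatic carbon. Among the measured compounds shown here, no measured step involves a hydroxy at this position; the only step that touches this ring, a 1.5-fold higher number from compound 2 to compound 3 (0.17 log units; within the scatter), was within the scatter, so it gives no sign that changes here move the number. Compound 4 is therefore expected to show a step of a 1.0-fold lower number from compound 3 to compound 4 (0.01 log units; within the scatter), within the scatter. The estimated value of compound 4 in this assay is 9000 nM, with a range from 3000 nM to 27000 nM.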

Compound 4, half-maximal effective concentration: "not active" (no number reported)
Compound 4 has no reported number here; there is nothing to compare the estimate with.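

Among the compounds shown here, compound 4 carries no number in this assay, so no step from compound 3 to compound 4 can be read, and no evidence bears on this result. The compounds shown leave open how far compound 4 stands from compound 3.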